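Moving the methyl thiazole isomer on the ethoxy chain

A few compounds are considered here, and "the series" means these few. Any claim that something is new, unique, unknown or untested is made for them only; others in the source may bear on it.

Measured in a toxicity assay on MT2 cells (Homo sapiens) for cytotoxicity, read by XTT assay, with a stated time of 4 days (on this read-out higher numbers stand for lower toxicity in this test and lower numbers for higher toxicity in this test), both values are limits:
compound 1 (`Cc1nc(C)c([C@H](OC(C)(C)C)C(=O)O)c(N2CCC(C)(C)CC2)c1-c1ccc(OCCc2cc(F)ccc2F)cc1`): >= 33500 nM (a limit)
compound 2 (`Cc1nc(CCOc2ccc(-c3c(C)nc(C)c([C@H](OC(C)(C)C)C(=O)O)c3N3CCC(C)(C)CC3)cc2)cs1`): >= 25000 nM (a limit)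

Compound 2 stands at the limit of >= 25000 nM and has no exact number. Compound 3 (`Cc1ncsc1CCOc1ccc(-c2c(C)nc(C)c([C@H](OC(C)(C)C)C(=O)O)c2N2CCC(C)(C)CC2)cc1`) differs from it as follows: 4-methyl-1,3-thiazol-5-yl in place of 2-methyl-1,3-thiazol-4-yl on a saturated chain carbon, two bonds along the chain from an oxygen on an aromatic ring, with 4-methyl-1,3-thiazol-5-yl in place of 2-methyl-1,3-thiazol-4-yl. Within the data shown here, the one measured step that bears on this is a step that the two limits leave unreadable from compound 1 to compound 2 and it gives no size. No change beyond the scatter, in either direction, is therefore expected in this assay. The expected step is a step that the limit leaves unreadable from compound 2 to compound 3 and no larger. Compound 3 is estimated at 30000 nM within 14000 nM to 60000 nM, and again only a limit may be expected.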

Compound 3, half-maximal cytotoxic concentration: >= 25000 nM
Compound 3: only a limit was reported; the forecaster's own chance of this, stated with the estimate: 75%; the middle value does not contradict the limit.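

Among these compounds, compound 1, compound 2 and compound 3 all carry limits only, so no step among them can be read. From the compounds shown here alone, whether 4-methyl-1,3-thiazol-5-yl, 2-methyl-1,3-thiazol-4-yl and 2,5-difluorophenyl differ at all in this assay remains open.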